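The compounds below may be only part of what the source reports. "The series", "measured", "known", "first", "only" and "open" are said of these compounds alone.

Of the compounds shown here, three with a shared core have been tested in an assay on membranes from CHO cells for displacement of a labelled ligand from adenosine receptor A1 (Homo sapiens), read by scintillation counting, with a stated time of 60 min, tested at 1 uM; a lower number here means less inhibition, a higher number more inhibition at the concentration tested (going by the name of the read-out). Compound 1 `CCC(C)OC(=O)C1=C(C)NC(=O)NC1c1ccco1` gives 6%. Compound 2 `CC1=C(C(=O)OC2CCC2)C(c2ccco2)NC(=O)N1` gives 19%. Compound 3 `CCC(C)OC(=O)C1=C(C)NC(=O)NC1c1cccs1` gives 5%.

Compound 2 differs from compound 1 in one place, (cyclobutyl in place of sec-butyl on an oxygen next to a carbonyl group), and the reading moved by a number 13 percentage points higher from compound 1 to compound 2 (beyond the scatter). Compound 3 differs from compound 1 in the core, (thiophen-2-yl in place of furan-2-yl on a saturated ring carbon), and here the reading moved by only a number 1 percentage points lower from compound 1 to compound 3 (within the scatter), so compound 1 and compound 3 cannot be told apart on this read-out.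

Compound 4 `CC1=C(C(=O)OC2CCC2)C(c2cccs2)NC(=O)N1` has not yet been measured in this assay. It carries the core of compound 3 together with the change already seen between compound 1 and compound 2: cyclobutyl in place of sec-butyl on an oxygen next to a carbonyl group. The place of the change is the same in both pairs, an oxygen next to a carbonyl group whose other neighbour is the carbonyl carbon, so it is the same change on a core that differs only in the way just described.

Within the data shown here, on that basis the step from compound 3 to compound 4 is expected to be about a number 12 percentage points higher from compound 3 to compound 4 (beyond the scatter), alongside the measured step of a number 13 percentage points higher from compound 1 to compound 2 (beyond the scatter) on the other core, because the move from compound 1 to compound 2 of a number 13 percentage points higher from compound 1 to compound 2 (beyond the scatter) is the only guide available and the two cores gave indistinguishable readings. Compound 4 is therefore estimated at 17%, with a plausible range from 7% to 28%.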

Compound 4, a percentage reported as inhibition, at one concentration (the size of the read-out at that concentration, not a potency): 24%
For compound 4 the middle estimate is 7 percentage points below the measured one; low and high end bracket the measured number.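

In this assay, cyclobutyl in place of sec-butyl on the core of compound 3 gives a number 19 percentage points higher from compound 3 to compound 4 (beyond the scatter), and this step fits the one seen on the core of compound 1, as the two steps side by side show: the same change on two cores in this assay, a number 13 percentage points higher (beyond the scatter) from compound 1 to compound 2 and a number 19 percentage points higher (beyond the scatter) from compound 3 to compound 4, 6 percentage points apart, within the scatter of two such steps The other change also behaves alike in both settings, since thiophen-2-yl in place of furan-2-yl gives a number 5 percentage points higher from compound 2 to compound 4 (within the scatter), a step as small as the one seen with sec-butyl: the same change on two cores in this assay, a number 1 percentage points lower (within the scatter) from compound 1 to compound 3 and a number 5 percentage points higher (within the scatter) from compound 2 to compound 4, 6 percentage points apart, within the scatter of two such steps Within this set of four compounds the two changes therefore carry over from one core to the other, but that rests on just two closely related cores, and it does not show that the same would hold on a more different core, nor does it explain why cyclobutyl raises the reading, while the 24% of compound 4 is a size at one concentration and not a potency.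

The compounds shown leave open what other groups on that oxygen would do, such as cyclopentyl or a longer chain. They also leave open whether the cyclobutyl step would survive with a different group in place of furan-2-yl and thiophen-2-yl, such as phenyl.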